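Turning an acid into its ester on the piperidine side chain

A few compounds are considered here, and "the series" means these few. Any claim that something is new, unique, unknown or untested is made for them only; others in the source may bear on it.

Measured so far:
compound 1, `Cc1cc(C(=O)O)ccc1C(C)N1CCC[C@H](O[C@H](CO)c2cc(Cl)cc(Cl)c2)[C@@H]1c1ccccc1`: 18000 nM
compound 2, `Cc1cc(C(=O)O)ccc1CN1CCC[C@H](O[C@H](CO)c2ccccc2)[C@@H]1c1ccccc1`: 25000 nM

Both compounds were tested in an assay on isolated protein for activation of cGMP-dependent protein kinase 1 (Homo sapiens), read by ADP-Glo, with stated times of 30 min and 2 h, in the presence of a further agent that is not named here; a higher number here means that more compound is needed for the effect, a lower number that less compound is needed. Compound 1 gives 18000 nM there, and the number for compound 2 is within the usual scatter of that, so the two cannot be told apart on these measurements.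

Compound 3, `COC(=O)c1ccc(CN2CCC[C@H](O[C@H](CO)c3cc(Cl)cc(Cl)c3)[C@@H]2c2ccccc2)c(C)c1`, has not yet been measured. It differs from compound 1 in one place, on an amine nitrogen in a ring: a group of 12 heavy atoms (10 carbon, 2 oxygen; one six-membered aromatic ring of carbon only) in place of a group of 12 heavy atoms (10 carbon, 2 oxygen; one six-membered aromatic ring of carbon only), on an amine nitrogen in a ring. The two compounds share the same atoms, joined differently, and the change swaps one hydrogen-bond donor for a second hydrogen-bond acceptor.

Among the compounds with values here, no measured pair shows what such a swap does here, so the direction is open. A modest step toward a higher number is expected, a 1.9-fold higher number from compound 1 to compound 3 (0.29 log units; within the scatter), and compound 3 is estimated at 35000 nM, likely between 9000 nM and 120000 nM.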

Compound 3, half-maximal effective concentration: 900 nM
Compound 3: the middle estimate sits 39-fold (1.59 log units) above what was measured; the whole stated range lies above it.
By their numbers in this assay, from the lowest: compound 3; then compounds 1 and 2 (each within the scatter of the next).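

The group on the amine nitrogen in the six-membered ring clearly matters in this assay: rearranging the same atoms there gives a 20-fold lower number from compound 1 to compound 3 (1.30 log units; beyond the scatter), the first difference in this set that lies beyond the scatter. In this rearrangement, the carboxylic acid becomes a methyl ester and the methyl on the carbon linking the group to the nitrogen disappears, so a hydrogen-bond donor gives way to a further hydrogen-bond acceptor. No measurement here explains the size of this step.

Because both changes arrive together, the compounds shown cannot separate the effect of the ester from that of losing the linking methyl. An unbranched carboxylic acid carrying the 1-(3,5-dichlorophenyl)-2-hydroxyethoxy group would address this, while an amide or ethyl ester would test how specific the methyl ester is.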